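A few compounds are considered here, and "the series" means these few. Any claim that something is new, unique, unknown or untested is made for them only; others in the source may bear on it.

Working notes on the sulfonamide series.

Compound 1 `CCc1ccccc1N(CC(=O)NCc1cccc(OC)c1)S(=O)(=O)c1ccc(C)cc1` and compound 2 `CCc1ccccc1N(CC(=O)NCc1ccc(Cl)cc1)S(=O)(=O)c1ccc(C)cc1` share the same core and differ only in the aryl on the saturated chain carbon bound to the amide-type nitrogen. In an assay on CHO cells for displacement of a labelled ligand from prostaglandin E2 receptor EP1 subtype (Homo sapiens) (on this read-out lower numbers stand for stronger inhibition and higher numbers for weaker inhibition), compound 1 gives 79.4 nM and compound 2 gives 10 nM. Among the compounds with values here, the step of a 7.9-fold lower number from compound 1 to compound 2 (0.90 log units; beyond the scatter) is the only measured change so far. Among the two numbers compound 2 stands lowest, with compound 1 as its only neighbour.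

Compound 3 `Cc1ccc(S(=O)(=O)N(CC(=O)NCc2ccc(Cl)cc2)c2ccccn2)cc1` keeps the 4-chlorophenyl of compound 2 and changes a different position: pyridin-2-yl in place of 2-ethylphenyl on a sulfonamide nitrogen. Within the data shown here, no measured step touches the group on the sulfonamide nitrogen, so the single step from compound 1 to compound 2 does not bear on this change; it only shows that the 4-chlorophenyl side is already held at its better setting. Among the measured compounds shown here, with no precedent at this position, the expectation for this assay rests on the fact that the group leaving carries an extra ring substituent and the group entering does not, and is held loosely.

Compound 3 is expected to give 40 nM in this assay, within 8 nM to 200 nM, a step of a 4.0-fold higher number from compound 2 to compound 3 (0.60 log units; beyond the scatter) from compound 2 that may well fall within the scatter.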

Compound 3, inhibition constant: < 1000 nM
Compound 3: a limit, no number; the forecaster's own chance of this, stated with the estimate: 5%; the middle value lies beyond the limit too.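

In this assay compound 3 gives < 1000 nM, which is a limit of the assay and not a number. The step from compound 2 to compound 3 therefore cannot be read. The compounds shown leave open how far pyridin-2-yl in place of 2-ethylphenyl on the sulfonamide nitrogen moves this read-out, in either direction.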